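The compounds below may be only part of what the source reports. "The series", "measured", "known", "first", "only" and "open" are said of these compounds alone.

In a functional assay on A-375 cells (Homo sapiens) for antiproliferative activity (on this read-out lower numbers stand for stronger inhibition and higher numbers for weaker inhibition), three compounds built on a shared core have been measured so far. Compound 1 (`O=C(Nc1ccc(-c2cscn2)cc1)C1CCN(Cc2ccc(F)c(F)c2)C1`) gives 10000 nM, the highest number of the three, and compound 2 (`O=C(Nc1ccc(-c2cscn2)cc1)[C@H]1CCCN(Cc2ccc(F)c(F)c2)C1`) gives 190 nM, the lowest. Compound 3 (`O=C(Nc1ccc(-c2cscn2)cc1)C1CCCN(Cc2ccccc2F)C1`) sits between them at 4000 nM. Its gaps to both neighbours lie beyond the scatter, though it is much closer to compound 1 than to compound 2.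

Compound 4 (`O=C(Nc1ccc(-c2cscn2)cc1)C1CCCN(Cc2cc(F)cc(F)c2)C1`) has not yet been measured. It differs from compound 3 by a single change, (3,5-difluorophenyl in place of 2-fluorophenyl on a saturated chain carbon bound to an amine nitrogen in a ring), with 3,5-difluorophenyl in place of 2-fluorophenyl on a saturated chain carbon bound to an amine nitrogen in a ring. Among the measured compounds shown here, no measured pair isolates this change, so the expectation rests on a looser comparison with compound 2, which also carries a difluorophenyl group and reads 190 nM in this assay. A shift toward stronger inhibition, beyond the scatter, is therefore expected, with an estimated 5.0-fold lower number from compound 3 to compound 4 (0.70 log units; beyond the scatter). Compound 4 is estimated at 800 nM, with an expected range of 200 nM to 3000 nM.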

Compound 4, half-maximal inhibitory concentration: 1360 nM
Beside the measured number, compound 4's estimate is 1.7-fold (0.23 log units) below it; measured number inside the range.
By their numbers in this assay, from the lowest: compound 2; then compound 4; then compound 3; then compound 1.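

In this assay, the shared core now has its first single-place comparison, a 2.9-fold lower number from compound 3 to compound 4 (0.47 log units; beyond the scatter). The step shows that the aromatic group on a saturated chain carbon bound to an amine nitrogen in a ring affects the read-out, with 3,5-difluorophenyl giving stronger inhibition than 2-fluorophenyl by more than the usual scatter. Nothing available explains this shift.

The change alters both the number of fluorines and where they sit, and this single step cannot separate those two contributions. Going by these compounds, it also remains open how this position would respond to other groups in place of 3,5-difluorophenyl, such as 3,5-dichlorophenyl, a methoxy-substituted phenyl or a phenyl ring with no fluorine.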